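Replacing One Ether Side Group on a Shared Core

The compounds below may be only part of what the source reports. "The series", "measured", "known", "first", "only" and "open" are said of these compounds alone.

In a functional assay on RAW264.7 cells (Mus musculus) for inhibition, read by Griess assay, with stated times of 1 h and 24 h (on this read-out lower numbers stand for stronger inhibition and higher numbers for weaker inhibition), compound 2 (`CC(C)=CCOc1ccccc1C1CC(=O)c2ccccc2O1`) gives 32700 nM and compound 1 (`CC(C)c1ccc(COc2ccccc2C2CC(=O)c3ccccc3O2)cc1`) gives 27100 nM, so these two values stand within the usual scatter of each other. Compound 3 (`O=C1CC(c2ccccc2OCc2ccccc2)Oc2ccccc21`) puts phenyl in place of 2-methylprop-1-en-1-yl on a saturated chain carbon bound to an oxygen on an aromatic ring. For the measured compounds named here, the one measured step at this place, a 1.2-fold higher number from compound 1 to compound 2 (0.08 log units; within the scatter), exchanged 4-isopropylphenyl for 2-methylprop-1-en-1-yl, so no change beyond the scatter is expected in this assay. The expected step is small, a 1.1-fold lower number from compound 2 to compound 3 (0.04 log units; within the scatter). For compound 3 the estimated value is 30000 nM, with an expected range of 14000 nM to 60000 nM.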

Compound 3, half-maximal inhibitory concentration: 18900 nM
Beside the measured number, compound 3's estimate is 1.6-fold (0.20 log units) above it, and the stated range covers the measured number.
By their numbers in this assay, from the lowest: compounds 3, 1 and 2 (each within the scatter of the next).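

In this assay, phenyl in place of 2-methylprop-1-en-1-yl gives a small step (a 1.7-fold lower number from compound 2 to compound 3 (0.24 log units; within the scatter)), and hydrogen in place of isopropyl on an aromatic carbon gives another (a 1.4-fold lower number from compound 1 to compound 3 (0.16 log units; within the scatter)). This place on the shared core has now carried a group with no ring, a phenyl and a 4-isopropylphenyl, and all three compounds lie within the scatter of one another. No evidence on the reason is available. On these data alone, what an amine or a carboxylic acid on the side group would do remains open, as does the result of a longer chain.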